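Cyclopentylamino for pyrrolidin-1-yl on a shared core

The compounds below may be only part of what the source reports. "The series", "measured", "known", "first", "only" and "open" are said of these compounds alone.

Compound 1 `Nc1nc(OCC(F)(F)F)c2ncn(/C=C3/CC3(CO)CO)c2n1`: > 20000 nM
Compound 2 `Nc1nc(OCc2ccccc2)c2ncn(/C=C3/CC3(CO)CO)c2n1`: > 20000 nM
Compound 3 `Nc1nc(N2CCCC2)c2ncn(/C=C3/CC3(CO)CO)c2n1`: > 24000 nM
Compound 4 `Nc1nc(NC2CCCC2)c2ncn(/C=C3/CC3(CO)CO)c2n1`: not yet measured

All three measured compounds were tested in an ADME assay on Akata cells (Homo sapiens) for cytotoxicity, with a stated time of 7 days (on this read-out higher numbers stand for lower toxicity in this test and lower numbers for higher toxicity in this test), and none of them gave a number, only a limit. Compound 3 stands at > 24000 nM, which is a limit. Its place among the three therefore cannot be ranked.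

The change that leads to compound 4 is cyclopentylamino in place of pyrrolidin-1-yl on an aromatic carbon. The closest evidence comes from two exchanges on an aromatic carbon, a step that the two limits leave unreadable from compound 1 to compound 3 and a step that the two limits leave unreadable from compound 2 to compound 3. A third comparison, a step that the two limits leave unreadable from compound 1 to compound 2, concerns the chain bound to an oxygen on an aromatic ring. None of these three has a readable size, so they point in no direction. On this basis, no step beyond the usual scatter is expected in this assay, and another limit is the most likely report. The expected step is an at least 1.0-fold lower number from compound 3 to compound 4 (0.03 log units; that floor lies within the scatter). Compound 4 is estimated at 22000 nM, with an expected range from 9000 nM to 40000 nM.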

Compound 4, half-maximal cytotoxic concentration: > 20000 nM
Compound 4: only a limit was reported; the forecaster's own chance of this, stated with the estimate: 70%; the middle value does not contradict the limit.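

In this assay compound 4 gives only a limit, > 20000 nM, so none of its steps to compound 1, compound 2 or compound 3 can be read. The compounds shown leave open how compound 1, compound 2, compound 3 and compound 4 rank against one another in this test.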